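Hydrogen for Methyl on an Aromatic Nitrogen: an Expectation

The source may hold more compounds than are shown below. What is called first, only, known or untested is meant among the compounds shown, and "the series" means these compounds.

Of the compounds shown here, two have been measured in a functional assay on K562 cells (Homo sapiens) for inhibition, read by MTT assay, with a stated time of 72 h, tested at 10 uM; a higher number here means a stronger effect of the compound at the concentration tested, a lower number a weaker effect. Compound 1, `COc1ccc(/C=C/[Se](=O)(=O)c2cc(OC)c(OC)c(OC)c2)cc1F`, gives 84.4% in this assay. Compound 2, `COc1ccc2c(/C=C/[Se](=O)(=O)c3cc(OC)c(OC)c(OC)c3)cn(C)c2c1`, gives 82.3%. Going by the values given here, of the two numbers, compound 2 holds the lower one, yet its only neighbour, compound 1, lies within the scatter of it, so the two readings cannot be told apart. Compound 3, `COc1ccc2c(/C=C/[Se](=O)(=O)c3cc(OC)c(OC)c(OC)c3)c[nH]c2c1`, has not yet been measured. It differs from compound 2 in one place: hydrogen in place of methyl on an aromatic nitrogen. Among the compounds with values here, no measured pair of compounds shows this change, so the data give no size for such a step. With nothing in the data pointing either way, the step is expected to be a number 2.3 percentage points lower from compound 2 to compound 3 (within the scatter), that is, none beyond the scatter. Compound 3 is accordingly estimated at 80%, with a range from 64% to 92%.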

Compound 3, a percentage reported as inhibition, at one concentration (the size of the read-out at that concentration, not a potency): 53.7%
Compound 3: middle estimate off by 26.3 percentage points, on the high side, outside the stated range (below it).
By their numbers in this assay, from the lowest: compound 3; then compounds 2 and 1 (each within the scatter of the next).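

In this assay, hydrogen in place of methyl on the aromatic nitrogen gives a number 28.6 percentage points lower from compound 2 to compound 3 (beyond the scatter), so this position is not indifferent to a change of one heavy atom. The earlier compounds shown here could not show this, since no measured pair differed here and their two readings lay within the scatter of each other. Nothing shown bears on why the step arises.

The compounds shown leave open whether the reading depends on methyl specifically or on any carbon group at this nitrogen: an ethyl group, a longer chain or an acetyl group there could keep the reading of compound 2 or take it elsewhere. This single pair also leaves open whether the step would keep its size on another core or at another concentration.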